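The compounds below may be only part of what the source reports. "The series", "measured", "known", "first", "only" and "open" are said of these compounds alone.

Compound 1 `CC1=C(/C=C/C(=O)/C=C/c2ccc(Cl)cc2)C(C)(C)CCC1` gives 90600 nM in a functional assay on Hep cells (Homo sapiens) for cytotoxicity, read by sulforhodamine B assay, with a stated time of 48 h; on this read-out lower numbers stand for stronger inhibition and higher numbers for weaker inhibition. Compound 2 `CC1=C(/C=C/C(=O)/C=C/c2ccc(Br)cc2)C(C)(C)CCC1` gives 34500 nM in this assay, and compound 3 `CC1=C(/C=C/C(=O)/C=C/c2ccc(C#N)cc2)C(C)(C)CCC1` gives 45600 nM. Among the compounds with values here, the number of compound 3 lies within the scatter of the other two: a 2.0-fold lower number from compound 1 to compound 3 (0.30 log units; within the scatter) and a 1.3-fold higher number from compound 2 to compound 3 (0.12 log units; within the scatter), whereas the one step beyond the scatter is a 2.6-fold lower number from compound 1 to compound 2 (0.42 log units; beyond the scatter). Compound 4 `CC1=C(/C=C/C(=O)/C=C/c2ccc(C)cc2)C(C)(C)CCC1` differs from compound 3 by methyl in place of cyano on an aromatic carbon. Within the data shown here, no measured pair exchanges a cyano for a methyl, so the two steps that touch the cyano, both within the scatter, are the nearest guide, and no change beyond the scatter in this assay is expected. The estimated step, a 1.3-fold higher number from compound 3 to compound 4 (0.12 log units; within the scatter), is accordingly small. Compound 4 is expected to give about 60000 nM, with a range from 20000 nM to 180000 nM.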

Compound 4, half-maximal inhibitory concentration: 44100 nM
Beside the measured number, compound 4's estimate is 1.4-fold (0.13 log units) above it, within the range that was stated.
By their numbers in this assay, from the lowest: compounds 2, 4, 3 and 1 (each within the scatter of the next, the first and the last beyond it).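

At this aromatic carbon, para to a large group, methyl in place of cyano removes a hydrogen-bond acceptor, yet the number hardly moves (a 1.0-fold lower number from compound 3 to compound 4 (0.01 log units; within the scatter)). Methyl in place of bromo also stays within the scatter (a 1.3-fold higher number from compound 2 to compound 4 (0.11 log units; within the scatter)), while methyl in place of chloro goes just beyond it (a 2.1-fold lower number from compound 1 to compound 4 (0.31 log units; beyond the scatter)), so compound 1 is the only one of the four set apart from any other. Nothing available accounts for this. From the compounds shown here alone, whether an amine or a carboxylic acid here would stay in this range remains open, as does whether any group at this position moves the number much further.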